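A few compounds are considered here, and "the series" means these few. Any claim that something is new, unique, unknown or untested is made for them only; others in the source may bear on it.

The shared core of the series carries a varied aryl group; compound 1 `Cc1cc(-c2ccccc2C(F)(F)F)cc(C)c1Nc1ccnc(Nc2ccc(C#N)cc2)n1`, compound 2 `Cc1cccc(-c2cc(C)c(Nc3ccnc(Nc4ccc(C#N)cc4)n3)c(C)c2)c1` and compound 3 `Cc1cc(-c2cccc(F)c2)cc(C)c1Nc1ccnc(Nc2ccc(C#N)cc2)n1` differ only there. In an ADME assay on MT4 cells (Homo sapiens) for cytotoxicity, read by MTT assay, with a stated time of 4 days (on this read-out lower numbers stand for higher toxicity in this test and higher numbers for lower toxicity in this test), compound 1 gives 4210 nM, compound 2 gives 3670 nM and compound 3 gives 4120 nM. Going by the values given here, compound 2 holds the lowest of the three numbers, but a 1.1-fold lower number from compound 1 to compound 2 (0.06 log units; within the scatter) and a 1.1-fold higher number from compound 2 to compound 3 (0.05 log units; within the scatter) show that this low end sits within the scatter of the other two, and a 1.0-fold lower number from compound 1 to compound 3 (0.01 log units; within the scatter) likewise shows no real step. Among the compounds with values here, compound 4 `COc1ccccc1-c1cc(C)c(Nc2ccnc(Nc3ccc(C#N)cc3)n2)c(C)c1` has not yet been measured. 2-methoxyphenyl in place of 3-methylphenyl on an aromatic carbon The steps that bear on this change are the earlier aryl swaps, a 1.1-fold lower number from compound 1 to compound 2 (0.06 log units; within the scatter) and a 1.1-fold higher number from compound 2 to compound 3 (0.05 log units; within the scatter), neither of which moved the number beyond the scatter; no measured step brings an oxygen onto this ring, so that part of the change rests on nothing. For compound 4 in this assay no step beyond the scatter is therefore expected, a 1.0-fold higher number from compound 2 to compound 4 (0.02 log units; within the scatter). Compound 4 is estimated at 3800 nM, with a range of 1900 nM to 7600 nM.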

Compound 4, half-maximal cytotoxic concentration: 940 nM
The estimate for compound 4 lay 4.0-fold (0.61 log units) above the measured number; measured number below the stated range.
By their numbers in this assay, from the lowest: compound 4; then compounds 2, 3 and 1 (each within the scatter of the next).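

In this assay, this aryl position turns out to be able to move the number: a 3.9-fold lower number from compound 2 to compound 4 (0.59 log units; beyond the scatter), a 4.4-fold lower number from compound 3 to compound 4 (0.64 log units; beyond the scatter) and a 4.5-fold lower number from compound 1 to compound 4 (0.65 log units; beyond the scatter), although the three earlier aryl groups stayed within the scatter of one another. The 2-(trifluoromethyl)phenyl group of compound 1 stays with the 3-methylphenyl and 3-fluorophenyl groups, so a group at the ring place numbered 2 does not by itself set compound 4 apart; 2-methoxyphenyl is the only group shown with an oxygen and a hydrogen-bond acceptor. Nothing measured here explains this step.

Open, as far as these compounds go, is whether the lower number follows the methoxy group or its ring place, which 3-methoxyphenyl and 2-methylphenyl would separate. Also open, from the compounds shown here alone, is whether 2-ethoxyphenyl or 2-aminophenyl would track compound 4 or the other three.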